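The source may hold more compounds than are shown below. What is called first, only, known or untested is meant among the compounds shown, and "the series" means these compounds.

So far, two small compounds have numbers in a functional assay on NCI-H522 cells (Homo sapiens) for cytotoxicity, with a stated time of 3 days; a lower number here means a stronger inhibitor, a higher number a weaker inhibitor. Compound 1 `C#Cc1nc2ccccc2s1` gives 860 nM, and compound 2 `C=Cc1nc2ccccc2n1C` gives 2340 nM. Compound 2 therefore has the higher of the two numbers, which makes it the weaker inhibitor of the pair, and the gap lies beyond the usual scatter of repeated measurements. These two compounds differ in more than one place, so their gap cannot be pinned on any single change.

Compound 3 `Cn1c(I)nc2ccccc21`, not yet measured, differs from compound 2 in one place: iodo in place of vinyl on an aromatic carbon. The swap puts iodo where compound 2 carries vinyl, between two ring nitrogen atoms. Within the data shown here, no measured pair shows this swap, so the only anchor is compound 2 at 2340 nM. The likeliest outcome is a change no larger than the scatter, with a slight lean towards a higher number, and the expected step is a 1.5-fold higher number from compound 2 to compound 3 (0.17 log units; within the scatter). For compound 3 the estimate is 3500 nM, with an expected range from 1000 nM to 12000 nM.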

Compound 3, half-maximal inhibitory concentration: 1020 nM
Compound 3: middle estimate off by 3.4-fold (0.54 log units), on the high side, and the stated range covers the measured number.
By their numbers in this assay, from the lowest: compounds 1 and 3 (each within the scatter of the next); then compound 2.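

Among these compounds, this is the first measured change at this aromatic carbon, which sits between two ring nitrogen atoms, and in this assay it gives a 2.3-fold lower number from compound 2 to compound 3 (0.36 log units; beyond the scatter) when iodo stands in place of vinyl. The position therefore does not depend on vinyl or its double bond outside the aromatic rings to hold this level of cytotoxicity: a single iodine atom replaces two carbon atoms, and the number goes down rather than up. Among the compounds shown here, nothing measured so far speaks to the reason for this step.

As far as these compounds go, one swap at one position cannot separate a benefit specific to iodo from a simple benefit of losing vinyl, so it remains unknown how a plain hydrogen, chloro, an amine or a saturated chain such as ethyl would behave on the same carbon. For the compounds shown here, it is also open whether the step would keep its size and direction if the ring atom that bears a methyl group carried something else, since every comparison at this position so far rests on that methyl group being present.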